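Stepping from compound 1 toward compound 3 in microsomal clearance

A few compounds are considered here, and "the series" means these few. Any claim that something is new, unique, unknown or untested is made for them only; others in the source may bear on it.

Two compounds carry the same fluorinated dihydrobenzofuranylmethylamino side chain on different cores. Compound 1 `CN(c1ccn(C)n1)c1cnc(NCc2c(F)ccc3c2CCO3)c2cn[nH]c(=O)c12` was run in an ADME assay on microsomes from liver (Homo sapiens) for metabolic stability, read by LC-MS, using NADPH, with stated times of 5 min and 30 min, tested at 1 uM (on this read-out higher numbers stand for fast clearance and lower numbers for slow clearance), and there compound 1 gives 62 mL.min-1.g-1, the highest of the two numbers at hand. For the measured compounds named here, compound 2 `O=C(Nc1cnc(NCc2c(F)ccc3c2CCO3)n2cnnc12)c1ccccc1` is built on another core; in this assay compound 2 gives 10 mL.min-1.g-1, a lower number that lies beyond the usual scatter, though no single-point step connects these two structures.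

Compound 3 `Cc1nc(CN(C)C)ccc1-c1cnc(NCc2c(F)ccc3c2CCO3)c2cn[nH]c(=O)c12` has not yet been measured. It differs from compound 1 in one place: 6-((dimethylamino)methyl)-2-methylpyridin-3-yl in place of methyl(1-methyl-1H-pyrazol-3-yl)amino on an aromatic carbon. Going by the values given here, no measured pair shows what such an exchange does in this assay, so the expectation rests on compound 1 alone. Because compound 1 already sits at 62 mL.min-1.g-1, compound 3 is expected to stay in the same region of fast clearance, and the step from compound 1 to compound 3 is estimated as a 1.2-fold lower number from compound 1 to compound 3 (0.09 log units; within the scatter), a change within the scatter. Compound 3 is therefore estimated to give 50 mL.min-1.g-1 in this assay, with a likely range from 22 mL.min-1.g-1 to 110 mL.min-1.g-1.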

Compound 3, intrinsic clearance in microsomes: 13 mL.min-1.g-1
For compound 3 the middle estimate is 3.8-fold (0.59 log units) above the measured one; measured number outside the range, below it.
By their numbers in this assay, from the lowest: compounds 2 and 3 (each within the scatter of the next); then compound 1.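

The aromatic carbon para to a large group proves to be a place where the substituent matters in this assay: putting 6-((dimethylamino)methyl)-2-methylpyridin-3-yl in place of methyl(1-methyl-1H-pyrazol-3-yl)amino gives a 4.8-fold lower number from compound 1 to compound 3 (0.68 log units; beyond the scatter) and thus a clear shift toward slower clearance. The earlier compounds shown here offered no step of this kind, and this pair now ties a difference in clearance to a single place, with the core and the fluorinated side chain held the same. Nothing at hand shows which feature of the incoming group accounts for the lower number.

The exchange replaces the whole group at once, which leaves open whether the pyridine ring, its 2-methyl group or its dimethylaminomethyl arm carries the shift. Also open, on these data alone, is how a plain pyridin-3-yl, or a pyridine bearing a morpholinomethyl group in place of the dimethylaminomethyl arm, would read at this same aromatic carbon, and whether the shift would hold on another core.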